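Cyano for methyl on the pyrazole of an inactive amide

The source may report more compounds than this note shows. Statements on the series, on what has been measured and on what is new or still open speak of the compounds shown alone.

Measured compounds: compound 1 `O=C(N1CCCN(Cc2ccc(OCc3ccccc3)cc2)CC1)n1cccn1`, > 100000 nM; compound 2 `Cc1cnn(C(=O)N(C)CCN(C)Cc2cccc(OCc3ccccc3)c2)c1`, > 100000 nM.

In an assay on membranes from brain for binding affinity to neutral cholesterol ester hydrolase 1 (Mus musculus), read by fluorescence, with stated times of 1 h and 30 min (on this read-out lower numbers stand for stronger inhibition and higher numbers for weaker inhibition), compound 1 reports only a limit of the assay, > 100000 nM. In this assay compound 2 likewise reports only a limit, > 100000 nM. Compound 2 therefore stands at the limit where both shown values sit (the limit of > 100000 nM in this assay, at which 2 of the 2 values shown sit), so no measured step is available.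

Compound 3 `CN(CCN(C)C(=O)n1cc(C#N)cn1)Cc1cccc(OCc2ccccc2)c1` differs from compound 2 by cyano in place of methyl on an aromatic carbon. Among the measured compounds shown here, with no measured step to rest on, no change beyond the scatter is expected; compound 3 is estimated at 100000 nM, between 20000 nM and 500000 nM, a step from compound 2 of a number no higher from compound 2 to compound 3 (the limit leaves the size open) expected.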

Compound 3, half-maximal inhibitory concentration: > 100000 nM
Compound 3: a limit, no number (the forecaster's own chance of this, stated with the estimate: 75%); the middle value sits exactly at the limit.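

Compound 2 and compound 3 both report only limits of the assay, so the step between them cannot be read. The compounds shown leave open whether cyano in place of methyl changes inhibition at all.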